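The source may report more compounds than this note shows. Statements on the series, on what has been measured and on what is new or still open speak of the compounds shown alone.

Series notes, compound 2 to compound 3. In a functional assay on PANC-1 cells (Homo sapiens) for antiproliferative activity, read by MTT assay, with a stated time of 24 h (a lower number here means a stronger inhibitor, a higher number a weaker inhibitor), compound 1 `CC(=O)Oc1ccccc1C(=O)NCC[Se]C#N` gives 12100 nM and compound 2 `CC(=O)Oc1ccccc1C(=O)OCC[Se]C#N` gives 38700 nM; compound 2 therefore stands at the highest of the two numbers, with compound 1 the nearer by the step of a 3.2-fold higher number from compound 1 to compound 2 (0.50 log units; beyond the scatter). Compound 3 `CC(=O)Oc1ccccc1C(=O)[Se]CC[Se]C#N` is not yet measured. It differs from compound 2 by a group of 6 heavy atoms (3 carbon, 1 nitrogen, 2 selenium; no ring) in place of a group of 6 heavy atoms (3 carbon, 1 nitrogen, 1 oxygen, 1 selenium; no ring), on a carbonyl carbon. Within the data shown here, the one measured step that bears on this change is the earlier swap on the same carbonyl carbon, which moved this assay by a 3.2-fold higher number from compound 1 to compound 2 (0.50 log units; beyond the scatter); that step was modest but beyond the scatter, so a second swap at the same place is expected to move the number by a step of comparable size rather than leave it within the scatter. Direction cannot be read from one step. Compound 3 is estimated at 15000 nM, within 4000 nM to 55000 nM, meaning an expected step of a 2.6-fold lower number from compound 2 to compound 3 (0.41 log units; beyond the scatter).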

Compound 3, half-maximal inhibitory concentration: > 50000 nM
Compound 3: a limit, no number; the forecaster's own chance of this, stated with the estimate: 5%; at least 3.3-fold (0.52 log units) between middle value and limit.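

In this assay compound 3 gives a limit and not a number: the limit of > 50000 nM in this assay, at which 1 of the 3 values shown sits.

Read against the earlier compounds, the new step is an at least 4.1-fold higher number from compound 1 to compound 3 (0.61 log units; beyond the scatter), so a second replacement on the carbonyl carbon also leaves the number higher than for compound 1, which now has a step beyond the scatter to each of the other two compounds, and none of the three goes against this. The other step, an at least 1.2-fold higher number from compound 2 to compound 3 (0.11 log units; that floor lies within the scatter), gives only a floor, so compound 2 and compound 3 cannot be placed in order.

As far as these compounds go, how far compound 3 actually lies from compound 2 stays open, since the limit hides its true value. Also open, from the compounds shown here alone, is whether a sulfur-linked group or a longer chain on the carbonyl carbon would stay near compound 1 or move away from it as well.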